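Compound 3 and a new aryl group on the same ring carbon

A few compounds are considered here, and "the series" means these few. Any claim that something is new, unique, unknown or untested is made for them only; others in the source may bear on it.

Compound 1 `COC(OC)C1=C(C(=O)OC/C=C/c2ccccc2)C(c2cccc(Cl)c2)C(C(=O)O)=C(C)N1`: 3000 nM
Compound 2 `COC(OC)C1=C(C(=O)OC/C=C/c2ccccc2)C(c2ccc(Cl)cc2)C(C(=O)O)=CN1`: 1100 nM
Compound 3 `COC(OC)C1=C(C(=O)OC/C=C/c2ccccc2)C(c2cc(Cl)cc(Cl)c2)C(C(=O)O)=CN1`: 1000 nM

All three compounds were tested in an assay on IMR-32 cells for inhibition of Voltage-dependent N-type calcium channel subunit alpha-1B (Homo sapiens), with a stated time of 5 min; a higher number here means a weaker inhibitor, a lower number a stronger inhibitor. Compound 3 gives the lowest of the three numbers, but compound 2, its nearest neighbour, sits within the scatter of it, so no order between those two can be claimed. Compound 1 stands furthest away, beyond the scatter, and it also differs from compound 3 in more than one place, so its gap cannot be tied to a single change.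

Going by the values given here, only one measured step bears on the change considered here: a 1.1-fold lower number from compound 2 to compound 3 (0.04 log units; within the scatter). That step exchanged one chlorinated phenyl ring for another on the saturated ring carbon and stayed within the scatter.

Compound 4 `COc1ccc(C2C(C(=O)O)=CNC(C(OC)OC)=C2C(=O)OC/C=C/c2ccccc2)cc1Cl` differs from compound 3 in the same place: 3-chloro-4-methoxyphenyl in place of 3,5-dichlorophenyl on a saturated ring carbon. Among the compounds with values here, the entering group carries a methoxy group that no measured compound has, so the single comparable step is the only guide. On that basis a step of a 1.5-fold higher number from compound 3 to compound 4 (0.18 log units; within the scatter) is expected, that is, nothing beyond the scatter. Compound 4 is therefore estimated to give about 1500 nM, with a range from 500 nM to 4500 nM.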

Compound 4, half-maximal inhibitory concentration: 1500 nM
Estimate against measurement, compound 4: no gap at the digits printed; the range from low to high includes it.
By their numbers in this assay, from the lowest: compounds 3, 2, 4 and 1 (each within the scatter of the next, the first and the last beyond it).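

The piece shows a 1.5-fold higher number from compound 3 to compound 4 (0.18 log units; within the scatter) and a 1.4-fold higher number from compound 2 to compound 4 (0.13 log units; within the scatter) when 3-chloro-4-methoxyphenyl stands on this saturated ring carbon. Going by these compounds alone, earlier, the only readable step at this carbon exchanged one chlorinated phenyl ring for another, whereas the entering group now carries a methoxy group, with its 1 hydrogen-bond acceptor, and the number still does not move beyond the scatter. Compounds 2, 3 and 4 therefore cannot be placed in any order, and none of the three goes against this; compound 1 differs from them in more than one place, so it says nothing about this change.

Every aryl group shown still carries at least one chlorine, so it remains open what an unsubstituted phenyl ring, or a phenyl ring bearing an amine or a carboxylic acid, would do on this carbon, and whether any group here can move the number beyond the scatter. No independent measurement is available to explain why these three numbers lie so close together.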